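Methyl in Place of Cyano on the Aryl Arm

A few compounds are considered here, and "the series" means these few. Any claim that something is new, unique, unknown or untested is made for them only; others in the source may bear on it.

Compound 1 `N#Cc1ccc(-c2cs/c(=N/NC(=O)CSc3ncccn3)n2-c2ccccc2)cc1` was tested in an ADME assay on NIH3T3 cells (Mus musculus) for cytotoxicity, read by MTT assay, with a stated time of 24 h; on this read-out higher numbers stand for weaker inhibition and lower numbers for stronger inhibition. In this assay compound 1 gives < 3.9 ug/mL, which is a limit of the assay and not a number. Compound 2 `Cn1nnnc1SCC(=O)N/N=c1/scc(-c2ccc(C#N)cc2)n1-c1ccccc1` gives 213 ug/mL in this assay. Compound 3 `Cc1nnc(SCC(=O)N/N=c2/scc(-c3ccc(C#N)cc3)n2-c2ccccc2)s1` gives < 3.9 ug/mL in this assay, again a limit rather than a number. Compound 1 therefore stands at the strong end of the values shown, together with compound 3, both sitting at the limit of < 3.9 ug/mL in this assay, at which 2 of the 3 values shown sit. The measured steps all change the heteroaryl group on the sulfur: an at least 54-fold higher number from compound 1 to compound 2 (1.73 log units; beyond the scatter), an at least 54-fold lower number from compound 2 to compound 3 (1.73 log units; beyond the scatter), and a step that the two limits leave unreadable from compound 1 to compound 3. Compound 4 `Cc1ccc(-c2cs/c(=N/NC(=O)CSc3ncccn3)n2-c2ccccc2)cc1` differs from compound 1 elsewhere: methyl in place of cyano on an aromatic carbon. Among the measured compounds shown here, none of the measured steps touches the cyanophenyl arm, so they do not bear directly on this change and give no direction for it. Compound 4 is therefore expected to stay close to compound 1, with a step of an at least 1.0-fold higher number from compound 1 to compound 4 (0.01 log units; that floor lies within the scatter) that is expected not to go beyond the scatter. The estimate for compound 4 in this assay is 4 ug/mL, in a range from 1.5 ug/mL to 20 ug/mL, with a fair chance that only a limit is again reported.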

Compound 4, half-maximal inhibitory concentration: > 500 ug/mL
Compound 4: only a limit was reported; the forecaster's own chance of this, stated with the estimate: 45%; middle value at least 120-fold (2.09 log units) from the limit.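

In this assay, among the compounds shown here, methyl in place of cyano on an aromatic carbon, para to a large group, gives an at least 120-fold higher number from compound 1 to compound 4 (2.10 log units; beyond the scatter), so the aryl arm, which no earlier step touched, proves to be a position where a single small change has a large effect. Until now only a change of the group on the sulfur had moved a compound away from the strong end, whereas here the pyrimidin-2-yl on the sulfur stays in place and the change from 4-cyanophenyl to 4-methylphenyl alone reaches the weak end of the values shown. Compound 4 now stands at the opposite limit from compound 1, and this value too is a limit of the assay and not a number: the limit of > 500 ug/mL in this assay, at which 1 of the 4 values shown sits.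

The compounds shown leave open whether the same change acts alike when 1-methyl-1H-tetrazol-5-yl or 5-methyl-1,3,4-thiadiazol-2-yl sits on the sulfur, since the 4-methylphenyl arm appears here only with pyrimidin-2-yl. They also leave open how other groups at this carbon would fall between the two limits, such as a chlorine, a methoxy group, an amine or a carboxylic acid.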